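Hydroxyl for methoxy on the pendant aryl of compound 3

A few compounds are considered here, and "the series" means these few. Any claim that something is new, unique, unknown or untested is made for them only; others in the source may bear on it.

Of the compounds shown here, three built on a shared core have been measured in an assay for binding affinity to dual specificity mitogen-activated protein kinase kinase 4 (Homo sapiens), read by KINOMEscan, tested at 100 nM; on this read-out lower numbers stand for a stronger effect and higher numbers for a weaker effect at the one concentration tested. Compound 1 `CCCS(=O)(=O)Nc1ccc(F)c(C(=O)c2n[nH]c3ncc(-c4ccccc4F)cc23)c1F` gives 2%, compound 2 `CCCS(=O)(=O)Nc1ccc(F)c(C(=O)c2n[nH]c3ncc(-c4ccccc4OC)cc23)c1F` gives 1.9%, and compound 3 `CCCS(=O)(=O)Nc1ccc(F)c(C(=O)c2n[nH]c3ncc(-c4ccc(OC)cc4)cc23)c1F` gives 4.2%. The step of a number 2.2 percentage points higher from compound 1 to compound 3 (within the scatter) and the step of a number 2.3 percentage points higher from compound 2 to compound 3 (within the scatter) both stay within the scatter, so compound 3 sits among the other two rather than apart from them. Compound 4 `CCCS(=O)(=O)Nc1ccc(F)c(C(=O)c2n[nH]c3ncc(-c4cccc(O)c4)cc23)c1F` differs from compound 3 by 3-hydroxyphenyl in place of 4-methoxyphenyl on an aromatic carbon. The step of a number 2.3 percentage points higher from compound 2 to compound 3 (within the scatter), which moved a group around the same pendant ring, is the one that bears on this change, and it was small. The author therefore expects a step of a number 0.8 percentage points higher from compound 3 to compound 4 (within the scatter) that does not exceed the scatter. For compound 4 the estimate in this assay is 5%, ranging from 1.5% to 15%.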

Compound 4, a percentage reported as activity, at one concentration (the size of the read-out at that concentration, not a potency): 2.2%
The estimate for compound 4 lay 2.8 percentage points above the measured number; the measured number falls inside the stated range.
By their numbers in this assay, from the lowest: compounds 2, 1, 4 and 3 (each within the scatter of the next).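

In this assay, the 3-hydroxyphenyl group brings a hydrogen-bond donor that the earlier pendant groups lack, yet a number 2 percentage points lower from compound 3 to compound 4 (within the scatter) and a number 0.3 percentage points higher from compound 2 to compound 4 (within the scatter) and a number 0.2 percentage points higher from compound 1 to compound 4 (within the scatter) all stay small. At this position, then, neither the swap of methoxy for hydroxyl nor the donor it adds separates compound 4 from the other compounds. No evidence on hand accounts for this result.

Going by these compounds, whether 4-hydroxyphenyl would read the same as 3-hydroxyphenyl remains open, as does whether an amine or a carboxylic acid on the pendant ring would move the number beyond the scatter.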